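The source may hold more compounds than are shown below. What is called first, only, known or untested is meant among the compounds shown, and "the series" means these compounds.

Compound 3, `CC(C)N1CCN(CCCN(C[C@H]2Cc3ccccc3CN2)[C@H]2CCCc3cccnc32)CC1`, stands at the bottom of the three measured compounds in an ADME assay on microsomes from liver (Homo sapiens) for metabolic stability, read by LC-MS, with a stated time of 10 min, tested at 0.5 uM (a lower number here means that less of the compound is left, a higher number that more of the compound is left), with a value of 46%. Compound 1, `CN1CCN(CCCN(C[C@H]2Cc3ccccc3CN2)[C@H]2CCCc3cccnc32)CC1`, gives 72% in this assay, and compound 2, `c1ccc2c(c1)CN[C@@H](CN(CC[C@H]1CCCNC1)[C@H]1CCCc3cccnc31)C2`, gives 93%. The path to compound 3 ran downward in both directions: a number 26 percentage points lower from compound 1 to compound 3 (beyond the scatter), and a number 47 percentage points lower from compound 2 to compound 3 (beyond the scatter).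

Compound 4, `c1ccc2c(c1)CN[C@@H](CN(CCN1CCNCC1)[C@H]1CCCc3cccnc31)C2`, is not yet measured. It differs from compound 3 as follows: piperazin-1-yl in place of (4-isopropylpiperazin-1-yl)methyl on a saturated chain carbon, two bonds along the chain from an amine nitrogen. The isopropyl group that is tied to the modest fall in the step from compound 1 to compound 3 is gone here, and the remaining piperazin-1-yl carries a hydrogen-bond donor, as the piperidin-3-yl of compound 2 does. Both measured steps into compound 3 bear on this change, the first modest and the second large, and both point upward when read back toward compound 4. A step beyond the scatter in the upward direction is therefore expected in this assay, most likely of a size between the two observed steps.

For compound 4 the expected value in this assay is 78%, with a range from 60% to 94%, which corresponds to an expected step of a number 32 percentage points higher from compound 3 to compound 4 (beyond the scatter).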

Compound 4, percent of the compound remaining: 96%
Beside the measured number, compound 4's estimate is 18 percentage points below it; the whole stated range lies below it.
By their numbers in this assay, from the lowest: compound 3; then compound 1; then compounds 2 and 4 (each within the scatter of the next).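

In this assay, piperazin-1-yl on this saturated chain carbon, two bonds along the chain from an amine nitrogen, outdoes both alkylated groups, with a number 50 percentage points higher from compound 3 to compound 4 (beyond the scatter) and a number 24 percentage points higher from compound 1 to compound 4 (beyond the scatter). Set against piperidin-3-yl, the same place gives a number 3 percentage points higher from compound 2 to compound 4 (within the scatter), so these two different rings cannot be told apart in this read-out, and the high numbers are not tied to piperidin-3-yl alone. Across the four compounds, compound 2 and compound 4, which carry no alkyl group on the ring nitrogen, both stand above compound 1 and compound 3, and none of the four goes against this, but each step from an alkylated compound to compound 4 also replaces the longer link to the ring, as in 2-(4-isopropylpiperazin-1-yl)ethyl to (piperazin-1-yl)methyl.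

The compounds shown therefore leave open whether the alkyl group or the chain length carries the rise, a question that 4-methylpiperazin-1-yl or 4-isopropylpiperazin-1-yl at the place of the piperazin-1-yl of compound 4 would address, and they leave open how a morpholin-4-yl ring would read there. No measurement offered here gives a reason for any of these steps.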